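Fluoro in place of hydrogen on compound 2

A few compounds are considered here, and "the series" means these few. Any claim that something is new, unique, unknown or untested is made for them only; others in the source may bear on it.

In a functional assay on SJSA-1 cells (Homo sapiens) for antiproliferative activity, read by luminescence, with a stated time of 3 days (a higher number here means a weaker inhibitor of growth, a lower number a stronger inhibitor of growth), compound 1 (`CC(C)C1=C(C(=O)N2[C@H](C)CC[C@H]2C(=O)N2CCN(C)C3(CC3)C2)SC2=N[C@@](C)(c3ccc(Cl)cc3)[C@@H](c3ccc(Cl)cc3)N21`) gives 1080 nM and compound 2 (`CC(C)C1=C(C(=O)N2[C@H](C)CC[C@H]2C(=O)N2CCNC3(CC3)C2)SC2=N[C@@](C)(c3ccc(Cl)cc3)[C@@H](c3ccc(Cl)cc3)N21`) gives 650 nM so the two stand within the scatter of each other. Going by the values given here, the one measured step is a 1.7-fold lower number from compound 1 to compound 2 (0.22 log units; within the scatter) for hydrogen in place of methyl on an amine nitrogen in a ring, and it does not touch the aromatic ring. Compound 3 (`CC(C)C1=C(C(=O)N2[C@H](C)CC[C@H]2C(=O)N2CCNC3(CC3)C2)SC2=N[C@@](C)(c3ccc(Cl)cc3)[C@@H](c3ccc(Cl)c(F)c3)N21`) differs from compound 2 by fluoro in place of hydrogen on an aromatic carbon with fluoro in place of hydrogen on an aromatic carbon. No step beyond the scatter is therefore expected, and the estimated change is a 1.4-fold lower number from compound 2 to compound 3 (0.16 log units; within the scatter) at most. Compound 3 is expected at 450 nM in this assay with an estimated range of 170 nM to 1100 nM for repeated measurements.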

Compound 3, concentration for 50% growth inhibition in the SJSA-1 assay: 350 nM
The estimate for compound 3 lay 1.3-fold (0.11 log units) above the measured number, and the stated range covers the measured number.
By their numbers in the SJSA-1 assay, from the lowest: compounds 3, 2 and 1 (each within the scatter of the next, the first and the last beyond it).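

The first change shown on this aromatic ring, 4-chlorophenyl to 4-chloro-3-fluorophenyl, gives in the SJSA-1 assay a 1.9-fold lower number from compound 2 to compound 3 (0.27 log units; within the scatter), with compound 2 at 650 nM and compound 3 at 350 nM, so fluoro ortho to a chloro group leaves growth inhibition within the scatter. In a physicochemical assay for solubility, read by HPLC, in phosphate buffer, at pH 6.8, tested at 10 mM (on this read-out higher numbers stand for higher solubility and lower numbers for lower solubility), the same change gives a 1.1-fold lower number from compound 2 to compound 3 (0.04 log units; within the scatter), with compound 2 at 56 ug/mL and compound 3 at 51 ug/mL, which shows that solubility also stays within the scatter at this position. Nothing available offers an explanation for either result. The compounds shown leave open whether a methoxy group or a nitrile on this carbon would move either number beyond the scatter.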